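The source may hold more compounds than are shown below. What is called first, only, known or untested is meant among the compounds shown, and "the series" means these compounds.

Measured compounds and their values in an ADME assay on the whole organism (plasma) for pharmacokinetics, with Rattus norvegicus as the target, with a stated time of 6 h, at a dose of 10 mg/kg by the oral route; a higher number here means more compound in the circulation at the dose given, a lower number less compound in the circulation:

compound 1, `Cc1nc(N(C)C)nc(N[C@@H]2C[C@H](CO)[C@@H](O)[C@H]2O)c1-c1nc2cnccc2s1`, gives 3120 ng.h/mL.
compound 2, `Cc1nc(NC2CC2)nc(N[C@@H]2C[C@H](CO)[C@@H](O)[C@H]2O)c1-c1nc2cnccc2s1`, gives 600 ng.h/mL.
compound 3, `Cc1nc(N(C)Cc2ccccc2)nc(N[C@@H]2C[C@H](CO)[C@@H](O)[C@H]2O)c1-c1nc2cnccc2s1`, gives 98.5 ng.h/mL.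

Compound 1 has the highest number of the three, with compound 2 nearest and compound 3 furthest from it. Compound 4, `Cc1nc(N[C@@H](C)c2ccccc2)nc(N[C@@H]2C[C@H](CO)[C@@H](O)[C@H]2O)c1-c1nc2cnccc2s1`, differs from compound 1 in one place: (1-phenylethyl)amino in place of dimethylamino on an aromatic carbon.

Among the measured compounds shown here, two measured steps bear on this change. Replacing dimethylamino with an amine carrying one hydrogen gave a 5.2-fold lower number from compound 1 to compound 2 (0.72 log units; beyond the scatter). Adding a phenyl on the saturated chain carbon bound to the ring nitrogen gave a 32-fold lower number from compound 1 to compound 3 (1.50 log units; beyond the scatter). Compound 4 combines both features, so a large drop in this assay is expected, in the order of a 26-fold lower number from compound 1 to compound 4 (1.41 log units; beyond the scatter). Compound 4 is therefore estimated at 120 ng.h/mL, within a range from 30 ng.h/mL to 500 ng.h/mL.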

Compound 4, area under the concentration-time curve: 49.3 ng.h/mL
For compound 4 the middle estimate is 2.4-fold (0.39 log units) above the measured one, within the range that was stated.
By their numbers in this assay, from the lowest: compounds 4 and 3 (each within the scatter of the next); then compound 2; then compound 1.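

In this assay, (1-phenylethyl)amino on this carbon between two ring nitrogen atoms gives a 63-fold lower number from compound 1 to compound 4 (1.80 log units; beyond the scatter), and changing only the nitrogen's cyclopropyl to 1-phenylethyl gives a 12-fold lower number from compound 2 to compound 4 (1.09 log units; beyond the scatter). Against benzyl(methyl)amino the step is a 2.0-fold lower number from compound 3 to compound 4 (0.30 log units; within the scatter), so the two amines carrying a phenyl ring cannot be told apart here, even though one keeps a nitrogen hydrogen and the other does not. Nothing available explains why the phenyl-bearing groups give such low numbers. Still open, going by these compounds, is how the mirror-image 1-phenylethyl group would compare, and whether a plain amino group or a morpholine ring would match dimethylamino.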